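Aromatic Ring Returns to the Carbonyl Carbon

The source may hold more compounds than are shown below. What is called first, only, known or untested is meant among the compounds shown, and "the series" means these compounds.

Of the compounds shown here, two sharing one core have been measured so far. Compound 1 `O=C(S[C@@]12CC[C@H](O)[C@@H]1C(=O)NC2=O)c1ccc(O)cc1` carries a 4-hydroxyphenyl on a carbonyl carbon, and in a functional assay on RAW264.7 cells (Mus musculus) for inhibition, read by Griess assay, with a stated time of 24 h (on this read-out higher numbers stand for weaker inhibition and lower numbers for stronger inhibition), compound 1 gives 71800 nM. Compound 2 `CC(=O)S[C@@]12CC[C@H](O)[C@@H]1C(=O)NC2=O` has a methyl in that place, and in this assay compound 2 gives 148000 nM. Of the two numbers, compound 2 holds the higher one, so its inhibition is the weaker; the step of a 2.1-fold higher number from compound 1 to compound 2 (0.31 log units; beyond the scatter) describes that change.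

Compound 3 `O=C(S[C@@]12CC[C@H](O)[C@@H]1C(=O)NC2=O)c1ccccc1Cl` differs from compound 2 by 2-chlorophenyl in place of methyl on a carbonyl carbon. For the measured compounds named here, this reverses the one measured step in kind: an aromatic ring comes back to the carbonyl carbon, though now bearing a chlorine rather than a hydroxyl. Because a 2.1-fold higher number from compound 1 to compound 2 (0.31 log units; beyond the scatter) accompanied the loss of an aromatic ring, regaining one is expected to bring a modestly lower number in this assay. The 2-chlorophenyl itself has not been tested, and the range stays wide. For compound 3 the estimated step is a 2.0-fold lower number from compound 2 to compound 3 (0.30 log units; within the scatter). Compound 3 is therefore expected to give about 75000 nM in this assay, within 30000 nM to 180000 nM.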

Compound 3, half-maximal inhibitory concentration: 127000 nM
Beside the measured number, compound 3's estimate is 1.7-fold (0.23 log units) below it; the measured number falls inside the stated range.
By their numbers in this assay, from the lowest: compounds 1, 3 and 2 (each within the scatter of the next, the first and the last beyond it).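

In this assay, 2-chlorophenyl in place of methyl on the carbonyl carbon gives a 1.2-fold lower number from compound 2 to compound 3 (0.07 log units; within the scatter), so adding this aromatic ring does not produce a change that can be told from the scatter. Replacing the 4-hydroxyphenyl with 2-chlorophenyl gives a 1.8-fold higher number from compound 1 to compound 3 (0.25 log units; within the scatter), which also stays within the scatter. Compound 3 therefore cannot be separated from either neighbour, even though the two neighbours themselves are separated by a 2.1-fold higher number from compound 1 to compound 2 (0.31 log units; beyond the scatter), and the data offer no independent measurement that could explain this.

From the compounds shown here alone, it remains open whether the separation of compound 1 from compound 2 goes with the aromatic ring, the hydroxyl on it, or the two together, since 4-hydroxyphenyl and 2-chlorophenyl differ both in the atom carried and in where it sits. A plain phenyl or a 4-chlorophenyl would help pull these apart, while a ring carrying an amine or a carboxylic acid, or a longer chain in place of methyl, would show whether this position can move the number well outside the narrow span seen so far.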